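Sulfonyl Substituent Exchange in a Triazole Series

A few compounds are considered here, and "the series" means these few. Any claim that something is new, unique, unknown or untested is made for them only; others in the source may bear on it.

The series is followed in an assay on HEK293 cells for inhibition of solute carrier family 22 member 12 (Homo sapiens); on this read-out lower numbers stand for stronger inhibition and higher numbers for weaker inhibition. Compound 1 `NS(=O)(=O)CSc1nnc(Br)n1Cc1ccc(Br)c2ccccc12` gives 365000 nM in this assay. Within the data shown here, compound 2 `O=S(=O)(O)CSc1nnc(Br)n1Cc1ccc(Br)c2ccccc12` gives 14400 nM and stands lowest of the two numbers so far; its only neighbour is compound 1, and the gap between them is a 25-fold lower number from compound 1 to compound 2 (1.40 log units; beyond the scatter), a hydroxy group entering in place of an amino group on the sulfonyl sulfur. The next compound, compound 3 `O=S(=O)(CSc1nnc(Br)n1Cc1ccc(Br)c2ccccc12)Nc1ccccc1`, differs from compound 2 by anilino in place of hydroxy on a sulfonyl sulfur. Among the measured compounds shown here, the one measured step that bears on this change is the same exchange run toward the hydroxy group, where the number fell sharply; here the hydroxy group leaves again and a nitrogen substituent returns, so a rise in the number is expected, though an anilino group is not an amino group and the size is uncertain. The expected step is a 10-fold higher number from compound 2 to compound 3 (1.02 log units; beyond the scatter) in this assay, toward weaker inhibition. Compound 3 is therefore estimated at 150000 nM, with a range from 30000 nM to 700000 nM.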

Compound 3, half-maximal inhibitory concentration: 15800 nM
The estimate for compound 3 lay 9.5-fold (0.98 log units) above the measured number, outside the stated range (below it).
By their numbers in this assay, from the lowest: compounds 2 and 3 (each within the scatter of the next); then compound 1.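

On the sulfonyl sulfur, hydroxy and anilino are not told apart in this assay, with a 1.1-fold higher number from compound 2 to compound 3 (0.04 log units; within the scatter) for this exchange. Nitrogen on the sulfur therefore does not by itself set the number: phenyl in place of hydrogen on the sulfonamide nitrogen gives a 23-fold lower number from compound 1 to compound 3 (1.36 log units; beyond the scatter) in this series. Among these three compounds, only compound 1, with its amino group on the sulfonyl sulfur, stands apart.

From the compounds shown here alone, it remains open whether the gain on the sulfonamide nitrogen needs the phenyl ring or would also come with a smaller group such as methyl. Also open, going by these compounds, is whether a carboxylic acid in place of the sulfonic acid of compound 2 would keep the number of compound 2. Nothing at hand bears on the reason for these steps.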